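Oxygen-bearing side chain: from compound 1 to compound 4

This account rests on a few compounds, and the source may have more. Where it says the series, first, only, none or still open, it means among the compounds named here.

Among the compounds with values here, compound 1 `CSc1ccccc1CSc1nc(-c2ccc(F)cc2)c(-c2ccncc2)[nH]1` gives 6700 nM in a functional assay (Homo sapiens) for inhibition (a lower number here means a stronger inhibitor, a higher number a weaker inhibitor), the highest number of the three measured so far. Compound 2 `C[S+]([O-])c1ccc(CSc2nc(-c3ccc(Cl)cc3)c(-c3ccncc3)[nH]2)cc1` reads 320 nM and compound 3 `CS(=O)(=O)c1ccc(CSc2nc(-c3ccc(Br)cc3)c(-c3ccncc3)[nH]2)cc1` reads 640 nM, both well beyond the scatter from compound 1. Compound 4 `C[S+]([O-])c1ccc(O)c(CSc2nc(-c3ccc(F)cc3)c(-c3ccncc3)[nH]2)c1` differs from compound 1 by a group of 10 heavy atoms (7 carbon, 2 oxygen, 1 sulfur; one six-membered aromatic ring of carbon only) in place of a group of 8 heavy atoms (7 carbon, 1 sulfur; one six-membered aromatic ring of carbon only), on a saturated chain carbon bound to a sulfur. Within the data shown here, no measured pair isolates this change. Among the measured compounds shown here, compound 4 carries the same oxidised sulfur group as compound 2 at 320 nM, so a sizeable move towards a lower number in this assay is expected, though the second oxygen has no measured counterpart. The expected change is a 7.4-fold lower number from compound 1 to compound 4 (0.87 log units; beyond the scatter). Compound 4 is estimated at 900 nM, with an expected range of 250 nM to 3500 nM.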

Compound 4, half-maximal inhibitory concentration: 1000 nM
Compound 4: the middle estimate sits 1.1-fold (0.05 log units) below what was measured; measured number inside the range.
By their numbers in this assay, from the lowest: compounds 2, 3 and 4 (each within the scatter of the next, the first and the last beyond it); then compound 1.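

In this assay, within the data shown here, the exchange on the saturated chain carbon bound to a sulfur gives a 6.7-fold lower number from compound 1 to compound 4 (0.83 log units; beyond the scatter), the first step that can be read between two measured compounds. The rest of compound 4 matches compound 1, so this position responds to the group it carries. No measurement on hand accounts for the size of this step.

Among these compounds, the single step carries both the oxygen on the sulfur and the hydroxyl group, and their shares remain unresolved. Also open, from the compounds shown here alone, is how an amine or a carboxylic acid in place of the hydroxyl group would read.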